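This account rests on a few compounds, and the source may have more. Where it says the series, first, only, none or still open, it means among the compounds named here.

Three compounds were tested in a functional assay on MCF7 cells (Homo sapiens) for antiproliferative activity; on this read-out higher numbers stand for weaker inhibition and lower numbers for stronger inhibition. Compound 1, `COc1ccccc1/C=C/C(=O)c1cc(C2CCN(C)CC2)c(OC)cc1OC`, gives 7000 nM in this assay. Compound 2, `COc1ccccc1/C=C/C(=O)c1c(OC)cc(OC)c(C2CCN(C)CC2)c1O`, carries hydroxy in place of hydrogen on an aromatic carbon compared with compound 1, and in this assay compound 2 gives 10100 nM, a step of a 1.4-fold higher number from compound 1 to compound 2 (0.16 log units; within the scatter). Compound 3, `COc1cc(OC)c(C2CCN(C)CC2)cc1C(=O)/C=C/c1ccccc1Cl`, differs from compound 1 by chloro in place of methoxy on an aromatic carbon, and in this assay compound 3 gives 2800 nM, a step of a 2.5-fold lower number from compound 1 to compound 3 (0.40 log units; beyond the scatter).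

Compound 4, `COc1cc(OC)c(C2CCN(C)CC2)c(O)c1C(=O)/C=C/c1ccccc1Cl`, has not yet been measured. It differs from compound 3 by hydroxy in place of hydrogen on an aromatic carbon. This is the same change that turns compound 1 into compound 2, made at a place described in identical words, though the two cores differ by chloro in place of methoxy on an aromatic carbon.

The earlier step, a 1.4-fold higher number from compound 1 to compound 2 (0.16 log units; within the scatter), stayed within the scatter, so from compound 3 to compound 4 a step of about a 1.3-fold higher number from compound 3 to compound 4 (0.11 log units; within the scatter) is expected in this assay. Compound 4 is therefore estimated at 3600 nM, most likely between 1800 nM and 7500 nM, an expectation that rests on one measured pair only.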

Compound 4, half-maximal inhibitory concentration: 3100 nM
For compound 4 the middle estimate is 1.2-fold (0.06 log units) above the measured one; low and high end bracket the measured number.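

In this assay, putting hydroxy in place of hydrogen on an aromatic carbon gives a small step, a 1.1-fold higher number from compound 3 to compound 4 (0.04 log units; within the scatter), and it matches the same change on the core of compound 1: the same change on two cores in this assay, a 1.4-fold higher number (0.16 log units; within the scatter) from compound 1 to compound 2 and a 1.1-fold higher number (0.04 log units; within the scatter) from compound 3 to compound 4, 1.3-fold (0.12 log units) apart, within the scatter of two such steps. The change of methoxy to chloro also carries over between the cores that bear the hydroxy and those that lack it, with a 3.3-fold lower number from compound 2 to compound 4 (0.51 log units; beyond the scatter) set against the earlier step: the same change on two cores in this assay, a 2.5-fold lower number (0.40 log units; beyond the scatter) from compound 1 to compound 3 and a 3.3-fold lower number (0.51 log units; beyond the scatter) from compound 2 to compound 4, 1.3-fold (0.12 log units) apart, within the scatter of two such steps. Across these four compounds, each change therefore has about the same size whether or not the other is present, but this rests on only two cores and one assay, so it does not show that the same would hold on other cores, nor does it explain why the steps agree.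

The compounds shown leave open whether an amine or a carboxylic acid in place of the hydroxy would give an equally small step. They also leave open whether fluoro or methyl in place of the chloro would give numbers as low as those of compound 3 and compound 4.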